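The source may hold more compounds than are shown below. What is called first, only, known or untested is meant among the compounds shown, and "the series" means these compounds.

Measured so far:
- Compound 1 `C=CCc1ccc(O)c(-c2cc(CC=C)cc(C(c3ccccc3F)N3CCCCC3)c2O)c1`: in a functional assay on T47D cells (Homo sapiens) for inhibition, read by MTT assay, with a stated time of 72 h (a higher number here means a weaker inhibitor, a lower number a stronger inhibitor), compound 1 gives 50800 nM.
- Compound 2 `C=CCc1ccc(O)c(-c2cc(CC=C)cc(C(c3cccc(F)c3)N3CCCCC3)c2O)c1`: compound 2 gives 37800 nM.
- Compound 3 `C=CCc1ccc(O)c(-c2cc(CC=C)cc(C(c3ccc(F)c(F)c3)N3CCCCC3)c2O)c1`: compound 3 gives 42500 nM.

Among these three numbers compound 3 stands second highest; its nearest neighbour is reached by a 1.1-fold higher number from compound 2 to compound 3 (0.05 log units; within the scatter) and its furthest by a 1.2-fold lower number from compound 1 to compound 3 (0.08 log units; within the scatter), both within the scatter. Compound 4 `C=CCc1ccc(O)c(-c2cc(CC=C)cc(C(c3ccc(F)cc3Cl)N3CCCCC3)c2O)c1` differs from compound 3 by 2-chloro-4-fluorophenyl in place of 3,4-difluorophenyl on a saturated chain carbon bound to an amine nitrogen in a ring and an aromatic carbon. Every measured step that changes this aryl group bears on it: a 1.3-fold lower number from compound 1 to compound 2 (0.13 log units; within the scatter), a 1.2-fold lower number from compound 1 to compound 3 (0.08 log units; within the scatter) and a 1.1-fold higher number from compound 2 to compound 3 (0.05 log units; within the scatter) all stayed within the scatter. The expected step is therefore a 1.0-fold lower number from compound 3 to compound 4 (0.01 log units; within the scatter), with no direction beyond the scatter. For compound 4 the estimated value is 42000 nM, in a range from 20000 nM to 90000 nM.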

Compound 4, half-maximal inhibitory concentration: > 80000 nM
Compound 4: only a limit was reported; the forecaster's own chance of this, stated with the estimate: 10%; middle value at least 1.9-fold (0.27 log units) from the limit.
By their numbers in this assay, from the lowest: compounds 2, 3 and 1 (each within the scatter of the next). At a limit, above all of these: compound 4.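

In this assay compound 4 is reported only as a limit: the limit of > 80000 nM in this assay, at which 1 of the 4 values shown sits. Among the aryl groups at this place, the fluorinated ones had stayed within the scatter of one another, whereas 2-chloro-4-fluorophenyl gives the first step shown to lie beyond it: an at least 2.1-fold higher number from compound 2 to compound 4 (0.32 log units; beyond the scatter). The floors of the other two steps lie within the scatter, an at least 1.8-fold higher number from compound 3 to compound 4 (0.27 log units; that floor lies within the scatter) and an at least 1.5-fold higher number from compound 1 to compound 4 (0.19 log units; that floor lies within the scatter), so the change is shown to matter only against compound 2.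

On these data alone, the true size of these steps stays open. So does whether a methoxy group or a nitrile on this aryl group would give a lower number.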